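A few compounds are considered here, and "the series" means these few. Any claim that something is new, unique, unknown or untested is made for them only; others in the source may bear on it.

Compound 1 `CO/N=c1\[nH]cnc2c1[n+](C/C=C(\C)CC/C=C(/C)CCC=C(C)C)cn2C` and compound 2 `CC(C)=CCC/C(C)=C\CC/C(C)=C/C[n+]1cn(C)c2nc[nH]/c(=N\OCc3ccccc3)c21` share a core and differ in one place, (phenyl in place of hydrogen on a saturated chain carbon bound to an oxygen). In a functional assay on CEM/s cells (Homo sapiens) for cytotoxicity (on this read-out higher numbers stand for weaker inhibition and lower numbers for stronger inhibition), compound 1 gives 1230 nM, whereas compound 2 gives 10000 nM, and the change produced an 8.1-fold higher number from compound 1 to compound 2 (0.91 log units; beyond the scatter). Compound 3 `CO/N=c1\[nH]cnc2c1[n+](C/C=C(\C)CC/C=C(\C)CC/C=C(\C)CCC=C(C)C)cn2CCC#N` gives 5360 nM in this assay; the difference between its core and the core of compound 1 is not broken down here. Compound 4 `CC(C)=CCC/C(C)=C/CC/C(C)=C/CC/C(C)=C/C[n+]1cn(CCC#N)c2nc[nH]/c(=N\OCc3ccccc3)c21` is built from compound 3 by the same change, (phenyl in place of hydrogen on a saturated chain carbon bound to an oxygen), which among these compounds occurs twice in all. Given that compound 2 sits at 10000 nM and that the earlier step was an 8.1-fold higher number from compound 1 to compound 2 (0.91 log units; beyond the scatter), the step from compound 3 to compound 4 in this assay is expected to be a 4.7-fold higher number from compound 3 to compound 4 (0.67 log units; beyond the scatter). Compound 4 is therefore estimated at 25000 nM, likely between 8000 nM and 80000 nM.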

Compound 4, half-maximal inhibitory concentration: 19100 nM
Estimate against measurement, compound 4: 1.3-fold (0.12 log units) above, within the range that was stated.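

In this assay, methoxy to benzyloxy on the core of compound 3 gave a 3.6-fold higher number from compound 3 to compound 4 (0.55 log units; beyond the scatter), the same direction as the earlier 8.1-fold higher number from compound 1 to compound 2 (0.91 log units; beyond the scatter). Set side by side, the two steps do not differ beyond what repeated measurements would allow: the same change on two cores in this assay, an 8.1-fold higher number (0.91 log units; beyond the scatter) from compound 1 to compound 2 and a 3.6-fold higher number (0.55 log units; beyond the scatter) from compound 3 to compound 4, 2.3-fold (0.36 log units) apart, within the scatter of two such steps This shows that the change carried over between these two cores as a shift toward weaker inhibition, but two pairs cannot show that it would hold on any other core, and they do not explain the shift.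

The compounds shown leave open how an ethoxy group would compare with methoxy and benzyloxy on these cores. They also leave open whether an amine or a carboxylic acid on the phenyl ring would alter the step.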